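Chromane amines in a whole-animal dose series

The source may hold more compounds than are shown below. What is called first, only, known or untested is meant among the compounds shown, and "the series" means these compounds.

Measured so far in a functional assay on the whole organism with Mus musculus as the target; on this read-out lower numbers stand for an effect already at smaller amounts and higher numbers for an effect only at larger amounts of compound:
compound 1 `Cc1cc(N)c(C)c2c1OC(C)(C)C2` gives 32.3 mg/kg
compound 2 `Cc1c(N)cc2c(c1C)OC(C)(C)C2` gives 24.4 mg/kg
compound 3 `Cc1c(C)c2c(c(C)c1N)CC(C)(CSc1ccccc1)O2` gives 24.7 mg/kg

Compound 3 sits second highest of the three numbers; its nearest neighbour is compound 2, and even the furthest, compound 1, lies within the scatter of it. Within the data shown here, the three values therefore cannot be ordered against each other, and no single-point step between measured compounds is available to calibrate the series.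

Compound 4 `Cc1c(C)c2c(c(C)c1N)CC(C)(CNc1ccccc1)O2` differs from compound 3 in one place: anilino in place of phenylsulfanyl on a saturated chain carbon bound to a saturated ring carbon. Among the measured compounds shown here, no measured pair tells what this exchange does in this assay , so nothing can be drawn from the existing numbers about its direction. The expectation is a step of no more than the usual scatter, in either direction, a 1.0-fold higher number from compound 3 to compound 4 (0.01 log units; within the scatter).

Compound 4 is accordingly estimated at 25 mg/kg in this assay , with a range from 12 mg/kg to 50 mg/kg, the width reflecting the absence of any matched pair on this kind of change.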

Compound 4, dose for 50% inhibition: 15.7 mg/kg
For compound 4 the middle estimate is 1.6-fold (0.20 log units) above the measured one; measured number inside the range.
By their numbers in this assay, from the lowest: compounds 4, 2, 3 and 1 (each within the scatter of the next, the first and the last beyond it).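

Among these compounds, this is the first matched pair, and it gives a first reading for a change on a saturated chain carbon bound to a saturated ring carbon. In this assay, anilino in place of phenylsulfanyl gives a 1.6-fold lower number from compound 3 to compound 4 (0.20 log units; within the scatter), so this read-out does not separate the two groups, although the exchange keeps the count of heavy atoms and adds a hydrogen-bond donor. No measurement at hand speaks to the reason for this step.

The compounds shown leave open how phenoxy, N-methylanilino or a longer chain carrying the phenyl ring would read at this place. As far as these compounds go, compound 1 and compound 2 differ from compound 3 and compound 4 in more than one place, so what the whole side chain contributes also stays open.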